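The source may hold more compounds than are shown below. What is called first, only, known or untested is meant among the compounds shown, and "the series" means these compounds.

Compound 1 `Cc1c(Cc2c(F)cccc2Cl)nc(SC2CCCC2)[nH]c1=O`: > 71000 nM (a limit)
Compound 2 `CCCSc1nc(C(CC)c2c(F)cccc2Cl)c(C)c(=O)[nH]1`: > 3000 nM (a limit)

In an ADME assay on MT4 cells (Homo sapiens) for activation, read by MTT assay (on this read-out lower numbers stand for higher toxicity in this test and higher numbers for lower toxicity in this test), compound 2 gives > 3000 nM, which is a limit and not a number. Compound 1 also gives only a limit, > 71000 nM. Neither compound therefore has an exact value, and compound 2 cannot be placed precisely on this scale.

Compound 3 `CCC(c1nc(SC2CCCC2)[nH]c(=O)c1C)c1c(F)cccc1Cl` differs from compound 2 in one place, with cyclopentyl in place of propyl on a sulfur. Within the data shown here, no measured pair shows this change, so any forecast is loose. The expectation of low toxicity in this assay leans on compound 1, with its limit of > 71000 nM. The estimated change, counted from the limit, is a step that the limit leaves unreadable from compound 2 to compound 3, expected to lie beyond the scatter and toward lower toxicity. The result may again be only a limit. For compound 3, the estimated value is 30000 nM, with an expected range from 8000 nM to 100000 nM.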

Compound 3, half-maximal cytotoxic concentration: > 3000 nM
Compound 3: a limit, no number; the forecaster's own chance of this, stated with the estimate: 70%; the middle value does not contradict the limit.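

In this assay, compound 3 gives only a limit, as do compound 1 and compound 2, so no step can be read from compound 2 or compound 1 to compound 3. The compounds shown leave open whether cyclopentyl in place of propyl on a sulfur changes toxicity in this test at all.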